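Swapping the Aryl Cap: From Pyridine Acid to Anisole

This account rests on a few compounds, and the source may have more. Where it says the series, first, only, none or still open, it means among the compounds named here.

Compound 1 `Cc1c(OCCCCOc2cncc(C(=O)O)c2)ccc(C(=O)CC(C)(C)C)c1O` is the weaker of the two measured compounds: in an assay for positive allosteric modulation of metabotropic glutamate receptor 2 (Rattus norvegicus) (on this read-out lower numbers stand for an effect already at smaller amounts and higher numbers for an effect only at larger amounts of compound), compound 1 gives 490 nM, the highest number of the two. Compound 2 `Cc1c(OCCCCOc2ccc(Cl)c(C(=O)O)c2)ccc(C(=O)CC(C)(C)C)c1O` gives 87 nM, and the step of a 5.6-fold lower number from compound 1 to compound 2 (0.75 log units; beyond the scatter) comes from placing 3-carboxy-4-chlorophenyl in place of 5-carboxypyridin-3-yl on an oxygen on a saturated carbon.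

Compound 3 `COc1ccc(OCCCCOc2ccc(C(=O)CC(C)(C)C)c(O)c2C)cc1` differs from compound 1 at the same place: 4-methoxyphenyl in place of 5-carboxypyridin-3-yl on an oxygen on a saturated carbon. Going by the values given here, this change is only partly covered by the single measured step. That step kept the carboxylic acid and exchanged the heteroaromatic ring for a carbon-only ring, and the number fell. Among the compounds with values here, compound 3 also moves to a carbon-only ring, but it drops the carboxylic acid and its hydrogen-bond donor altogether, and no measured pair shows what that costs or gains. The expectation for compound 3 is therefore a modest fall in the number at best, with a wide range, expressed as a 1.6-fold lower number from compound 1 to compound 3 (0.21 log units; within the scatter). Compound 3 is estimated at 300 nM, between 80 nM and 1200 nM.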

Compound 3, half-maximal effective concentration: > 10000 nM
Compound 3 was reported as a limit (the forecaster's own chance of this, stated with the estimate: 10%); middle value at least 33-fold (1.52 log units) away from the limit.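

Compound 3 stands at a limit of the read-out and not at a number: the limit of > 10000 nM in this assay, at which 1 of the 3 values shown sits.

In this assay, the exchange on the oxygen on a saturated carbon now gives an at least 20-fold higher number from compound 1 to compound 3 (1.30 log units; beyond the scatter), and the comparison with the chlorinated acid gives an at least 110-fold higher number from compound 2 to compound 3 (2.06 log units; beyond the scatter). The earlier pair showed only that this position tolerates a change of ring while the carboxylic acid stays, with the number moving modestly; the new result shows that the same position can also lose the effect almost entirely within the range tested, so the cap is far from indifferent. Among the three compounds, the two caps carrying a carboxylic acid give measured numbers and the 4-methoxyphenyl cap, which has none, does not, and no compound shown goes against this.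

The loss of the carboxylic acid and the arrival of the methoxy group come in one change in compound 3, so the compounds shown do not separate the two. Going by these compounds, it also remains open whether a tetrazole or a primary amide could stand in for the carboxylic acid on this cap.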